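Moving One Fluorine on the Stronger Compound

The source may report more compounds than this note shows. Statements on the series, on what has been measured and on what is new or still open speak of the compounds shown alone.

In a functional assay on DLD-1 cells (Homo sapiens) for antiproliferative activity, read by CellTiter-Glo, with a stated time of 72 h (on this read-out lower numbers stand for stronger inhibition and higher numbers for weaker inhibition), compound 1 (`CC1CCN(C2CCN(S(=O)(=O)c3ccccc3-c3ccc(C(F)(F)F)cc3)CC2)CC1`) gives 122 nM, while compound 2 (`Cc1cc(C)c(S(=O)(=O)N2CCC(N3CCC(Cc4ccc(F)cc4)CC3)CC2)c(C)c1`) gives 18 nM, the lower of the two numbers and so the stronger inhibition. Compound 3 (`Cc1cc(C)c(S(=O)(=O)N2CCC(N3CCC(Cc4ccccc4F)CC3)CC2)c(C)c1`), not yet measured, carries 2-fluorophenyl in place of 4-fluorophenyl on a saturated chain carbon bound to a saturated ring carbon. Among the measured compounds shown here, no measured pair shows what this change does. In this assay, the estimated step of a 1.4-fold higher number from compound 2 to compound 3 (0.14 log units; within the scatter) is slightly weaker and is expected to stay within the scatter. Compound 3 is expected at 25 nM, with an estimated range from 9 nM to 70 nM.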

Compound 3, half-maximal inhibitory concentration: 74 nM
For compound 3 the middle estimate is 3.0-fold (0.47 log units) below the measured one; measured number outside the range, above it.
By their numbers in this assay, from the lowest: compound 2; then compounds 3 and 1 (each within the scatter of the next).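

Where the fluorine sits matters here: the two compounds hold the same atoms, yet 2-fluorophenyl in place of 4-fluorophenyl on a saturated chain carbon bound to a saturated ring carbon gives, in this assay, a 4.1-fold higher number from compound 2 to compound 3 (0.61 log units; beyond the scatter). This position therefore responds to a shift of one atom within the group, not only to which atoms the group contains. Nothing available explains this step. Still open, going by these compounds, is how plain phenyl with no fluorine, or 4-chlorophenyl, would compare at this place.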